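The source may report more compounds than this note shows. Statements on the series, on what has been measured and on what is new or still open speak of the compounds shown alone.

Measured so far in a functional assay on BXPC-3 cells (Homo sapiens) for antiproliferative activity, read by sulforhodamine B assay, with a stated time of 72 h; a lower number here means a stronger inhibitor, a higher number a weaker inhibitor
- compound 1 `CC(C)(C)c1[nH]cnc1/C=c1\[nH]c(=O)/c(=C/c2cccc(C(=O)c3ccccc3)c2)[nH]c1=O` gives 0.63 nM
- compound 2 `CC(C)(C)c1[nH]cnc1/C=c1\[nH]c(=O)/c(=C/c2cccc(C(=O)N3CCCCC3)c2)[nH]c1=O` gives 100 nM
- compound 3 `CC(C)(C)c1[nH]cnc1/C=c1\[nH]c(=O)/c(=C/c2cccc(C(=O)c3cccnc3)c2)[nH]c1=O` gives 4.05 nM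

Compound 1 holds the lowest number of the three, with compound 3 nearest. Compound 4 `CC(C)(C)c1[nH]cnc1/C=c1\[nH]c(=O)/c(=C/c2cccc(C(=O)c3ccsc3)c2)[nH]c1=O` is not yet measured. Its change from compound 1 is thiophen-3-yl in place of phenyl on a carbonyl carbon. The closest measured precedent is the modest 6.4-fold higher number from compound 1 to compound 3 (0.81 log units; beyond the scatter), where pyridin-3-yl enters at the same place. The large 160-fold higher number from compound 1 to compound 2 (2.20 log units; beyond the scatter), with piperidin-1-yl, is a more distant guide. For the measured compounds named here, no measured compound carries thiophen-3-yl. A small to modest rise in this assay is therefore expected. The expected change is a 2.4-fold higher number from compound 1 to compound 4 (0.38 log units; beyond the scatter). For compound 4 the estimate is 1.5 nM, with an expected range of 0.5 nM to 5 nM.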

Compound 4, half-maximal inhibitory concentration: 1.56 nM
The estimate for compound 4 lay 1.0-fold (0.02 log units) below the measured number, and the stated range covers the measured number.
By their numbers in this assay, from the lowest: compound 1; then compound 4; then compound 3; then compound 2.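

In this assay, the carbonyl carbon accepts a five-membered aromatic ring carrying sulfur, with only a modest rise, a 2.5-fold higher number from compound 1 to compound 4 (0.39 log units; beyond the scatter). The same ring also places the new compound ahead of the pyridin-3-yl analogue, a 2.6-fold lower number from compound 3 to compound 4 (0.41 log units; beyond the scatter), and far ahead of the piperidine amide, a 64-fold lower number from compound 2 to compound 4 (1.81 log units; beyond the scatter). Ring size alone therefore does not set the number here, since aromatic rings of both sizes stay well clear of compound 2.

From the compounds shown here alone, whether furan-3-yl, thiophen-2-yl or a phenyl ring bearing a methoxy group or an amine would match benzoyl remains open. Nothing measured here explains these steps.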